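The source may report more compounds than this note shows. Statements on the series, on what has been measured and on what is new or still open speak of the compounds shown alone.

Measured in an ADME assay on Vero 76 cells (Chlorocebus sabaeus) for cytotoxicity, read by neutral red uptake; a lower number here means that less compound is tolerated, a higher number that more compound is tolerated:
- Compound 1 `OC[C@@]12C[C@@H]1[C@@H](n1cnc3c(NCc4ccccc4)nc(Cl)nc31)[C@H](O)[C@@H]2O`: > 100000 nM, a limit
- Compound 2 `CC(C)(O)[C@@H](Nc1nc(Cl)nc2c1ncn2[C@H]1[C@H](O)[C@H](O)[C@]2(CO)C[C@H]12)C1CC1`: > 100000 nM, a limit

Compound 2 has no exact value in this assay. Its result of > 100000 nM is a limit and not a number. Compound 3 `CC(C)(C)[C@H](Nc1nc(Cl)nc2c1ncn2[C@H]1[C@H](O)[C@H](O)[C@]2(CO)C[C@H]12)C1CC1` carries 1-cyclopropyl-2,2-dimethylpropyl in place of 1-cyclopropyl-2-hydroxy-2-methylpropyl on a nitrogen on an aromatic ring.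

Among the measured compounds shown here, only one measured step bears on this position, a step that the two limits leave unreadable from compound 1 to compound 2, and it offers no size to carry forward. The remaining guide is the limit of > 100000 nM in this assay, at which 2 of the 2 values shown sit, which shows that compound 1 and compound 2 share the same limit. A change beyond the usual scatter is therefore not expected, and no direction can be favoured. The expected step is a number no higher from compound 2 to compound 3 (the limit leaves the size open). The estimate for compound 3 is 100000 nM. The estimated range runs from 40000 nM to 200000 nM, and the assay may again report only a limit.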

Compound 3, half-maximal cytotoxic concentration: > 100000 nM
Compound 3 was reported as a limit (the forecaster's own chance of this, stated with the estimate: 75%); the middle value lies on the limit itself.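

In this assay compound 3 gives > 100000 nM and this is a limit, not a number. Compound 1 and compound 2 also stand as limits, so no step among these three compounds can be read. On these data alone, whether their true cytotoxic concentrations differ at all stays open.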